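Swapping fluoro for methoxy on the benzylsulfanyl arm

A few compounds are considered here, and "the series" means these few. Any claim that something is new, unique, unknown or untested is made for them only; others in the source may bear on it.

Of the compounds shown here, two sharing one core have been measured in a functional assay on SW-620 cells (Homo sapiens) for cytotoxicity, read by MTT assay, with stated times of 4 h and 72 h, tested at 5 uM; a lower number here means a stronger inhibitor, a higher number a weaker inhibitor. Compound 1, `Cc1cc(Nc2ccc(C(=O)/C=C/c3ccc4ccccc4c3)cc2)n2nc(SCc3ccc(Cl)cc3)nc2n1`, gives 570 nM, and compound 2, `Cc1cc(Nc2ccc(C(=O)/C=C/c3ccc4ccccc4c3)cc2)n2nc(SCc3ccc(F)cc3)nc2n1`, gives 320 nM. Among the compounds with values here, compound 2 holds the lowest of the two numbers, but the only step separating it from compound 1, a 1.8-fold lower number from compound 1 to compound 2 (0.25 log units; within the scatter), is one the scatter could account for, so the two cannot be ranked against each other on this evidence.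

Compound 3, `COc1ccc(CSc2nc3nc(C)cc(Nc4ccc(C(=O)/C=C/c5ccc6ccccc6c5)cc4)n3n2)cc1`, differs from compound 2 by methoxy in place of fluoro on an aromatic carbon. Within the data shown here, the single measured step concerns the same aromatic carbon and exchanged one halogen for another, and it stayed within the scatter. Among the measured compounds shown here, no measured pair tells how a methoxy behaves here, so the expectation for compound 3 rests on that one halogen step and on the general closeness of the two recorded values. Compound 3 is therefore expected to land close to compound 2, with a step of a 1.3-fold higher number from compound 2 to compound 3 (0.12 log units; within the scatter) that need not exceed the scatter. The estimate for compound 3 in this assay is 420 nM, with a range from 150 nM to 1200 nM.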

Compound 3, half-maximal inhibitory concentration: 250 nM
Compound 3: the middle estimate sits 1.7-fold (0.23 log units) above what was measured, and the stated range covers the measured number.
By their numbers in this assay, from the lowest: compounds 3, 2 and 1 (each within the scatter of the next, the first and the last beyond it).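

Putting methoxy in place of fluoro on the aromatic carbon para to a large group gives a 1.3-fold lower number from compound 2 to compound 3 (0.11 log units; within the scatter) in this assay, so a group that is not a halogen and that carries a hydrogen-bond acceptor can stand at this position without leaving the range of the fluoro compound. Set against chloro, the same group gives a 2.3-fold lower number from compound 1 to compound 3 (0.36 log units; beyond the scatter), a modest step but the first in this series to pass the scatter, while compound 2 remains within the scatter of both compound 1 and compound 3. The 4-fluorobenzyl and 4-methoxybenzyl arms therefore cannot be ranked against each other, whereas the 4-methoxybenzyl arm can be separated from the 4-chlorobenzyl arm, and nothing measured for these compounds bears on the reason for that difference.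

Going by these compounds, whether the position would accept a hydroxyl, an amine or a carboxylic acid in the same way, or a longer chain such as ethoxy in place of methoxy, remains open. Also open, on these data alone, is whether the methoxy-for-chloro step would recur on a core other than the shared one.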